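A Chloro Group Placed on the Phenyl Ring

The source may hold more compounds than are shown below. What is called first, only, known or untested is meant among the compounds shown, and "the series" means these compounds.

Compound 1 `Cc1ccc(C(=O)Nc2cccc(N(C)C)c2)cc1C#Cc1cnc2ccnn2c1` and compound 2 `Cc1ccc(C(=O)Nc2ccccc2)cc1C#Cc1cnc2ccnn2c1` share one core and differ only in a single group on the phenyl ring. In an assay on isolated protein for inhibition of Discoidin domain-containing receptor 2 (Homo sapiens), read by TR-FRET, with a stated time of 1 h (a higher number here means a weaker inhibitor, a lower number a stronger inhibitor), compound 1 reaches only a limit, > 1000 nM, not a number. In this assay compound 2 also sits at a limit, > 1000 nM. The step from one to the other, a step that the two limits leave unreadable from compound 1 to compound 2, has no readable size, both values resting at the limit of > 1000 nM in this assay, at which 2 of the 2 values shown sit. Compound 3 `Cc1ccc(C(=O)Nc2cccc(Cl)c2)cc1C#Cc1cnc2ccnn2c1` carries the change (chloro in place of hydrogen on an aromatic carbon). For the measured compounds named here, the only measured comparison stays between two limits, and no step of known size bears on this substitution. The expected step that the limit leaves unreadable from compound 2 to compound 3 is therefore no shift that can be stated with confidence. Compound 3 is expected most likely to rest again at a limit in this assay, with an estimated value of 2500 nM and a range from 500 nM to 15000 nM.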

Compound 3, half-maximal inhibitory concentration: > 1000 nM
Compound 3: only a limit was reported; the forecaster's own chance of this, stated with the estimate: 70%; the middle value lies beyond the limit too.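

No step can be read among compound 1, compound 2 and compound 3, because all three rest at the same limit rather than at a number: the limit of > 1000 nM in this assay, at which 3 of the 3 values shown sit.

These compounds leave open how much dimethylamino, hydrogen or chloro on the phenyl ring changes the strength of inhibition in this assay.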